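Changing the Chain-End Amine on a Shared Core

The compounds below may be only part of what the source reports. "The series", "measured", "known", "first", "only" and "open" are said of these compounds alone.

Compound 1 `COc1c(OCCCNCc2ccccc2)cc(O)c2c(=O)cc(-c3ccccc3)oc12`: 1570 nM
Compound 2 `CCN(CC)CCCCOc1cc(O)c2c(=O)cc(-c3ccccc3)oc2c1OC`: 1000 nM

Both values come from a functional assay on A549 cells (Homo sapiens) for cytotoxicity, read by MTT assay, with a stated time of 48 h; a lower number here means a stronger inhibitor, a higher number a weaker inhibitor. Compound 2 stands level with compound 1, since the two numbers lie within the usual scatter of each other. Compound 3 `COc1c(OCCCCN2CCN(C)CC2)cc(O)c2c(=O)cc(-c3ccccc3)oc12` is still unmeasured and differs from compound 2 at the end of the chain: 4-methylpiperazin-1-yl in place of diethylamino on a saturated chain carbon, four bonds along the chain from an oxygen on an aromatic ring.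

Going by the values given here, only one measured step bears on this change, and only loosely, since it involves a different pair of amine groups. That step, a 1.6-fold lower number from compound 1 to compound 2 (0.20 log units; within the scatter), shows that replacing one amine group with another left the number within the scatter. On that single precedent, no step beyond the scatter is expected in this assay, in either direction. The expected step is a 1.2-fold higher number from compound 2 to compound 3 (0.08 log units; within the scatter). Compound 3 is expected at about 1200 nM, with an estimated range of 500 nM to 3000 nM.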

Compound 3, half-maximal inhibitory concentration: 1500 nM
For compound 3 the middle estimate is 1.3-fold (0.10 log units) below the measured one, within the range that was stated.
By their numbers in this assay, from the lowest: compounds 2, 3 and 1 (each within the scatter of the next).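

With 4-methylpiperazin-1-yl in place of diethylamino on a saturated chain carbon, this assay still shows no real change (the step is a 1.5-fold higher number from compound 2 to compound 3 (0.18 log units; within the scatter)) and none against the benzylamino end either (a 1.0-fold lower number from compound 1 to compound 3 (0.02 log units; within the scatter)). The chain end has now carried a group with a six-membered non-aromatic ring holding 2 hetero atoms, and compounds 1, 2 and 3 all stand level, so across these three amines the choice of end group does not move the number beyond the scatter. No measurement is at hand that could explain this level reading.

From the compounds shown here alone, it remains open whether a chain end with no amine at all, such as a carboxylic acid, would also stand level with these three. Also open, going by these compounds, is how a longer chain carrying 4-methylpiperazin-1-yl would compare with compound 3.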